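The source may hold more compounds than are shown below. What is called first, only, known or untested is meant among the compounds shown, and "the series" means these compounds.

Compound 2 `CSc1nc(N)nc2c1ncn2/C=C1/CC1(CO)CO` carries a methylsulfanyl group on the shared core. In an ADME assay on CCRF-HSB-2 cells (Homo sapiens) for cytotoxicity, with a stated time of 7 days (on this read-out lower numbers stand for higher toxicity in this test and higher numbers for lower toxicity in this test), compound 2 gives > 100000 nM, which is a limit of the assay and not a number. Among the compounds with values here, compound 1 `CCCNc1nc(N)nc2c1ncn2/C=C1/CC1(CO)CO`, the only other measured compound, carries propylamino at that spot. Compound 1 gives > 20000 nM, which is also a limit. Compound 2 therefore has no exact place on the scale.

Compound 3 `CC(C)CNc1nc(N)nc2c1ncn2/C=C1/CC1(CO)CO` has isobutylamino in place of methylsulfanyl on an aromatic carbon. Within the data shown here, only one measured step bears on this change, a step that the two limits leave unreadable from compound 1 to compound 2, and it swaps the same methylsulfanyl for propylamino, in the opposite direction. With limits at both ends, that step gives no size to carry over, so the direction can only be a weak expectation. Compound 3 resembles compound 1 by name of group, so it is expected to sit near the limit of compound 1 and may well return only a limit in this assay. The expected change is an at least 2.5-fold lower number from compound 2 to compound 3 (0.39 log units; beyond the scatter), and it is only loosely defined. For compound 3 the estimate is 40000 nM, with an expected range of 10000 nM to 100000 nM.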

Compound 3, half-maximal cytotoxic concentration: > 20000 nM
Compound 3 was reported as a limit (the forecaster's own chance of this, stated with the estimate: 75%); the middle value is on the limit's open side.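

Within the data shown here, compound 1, compound 2 and compound 3 all give only limits in this assay, so no step among them can be read, either for isobutylamino in place of methylsulfanyl or for the added methyl. The compounds shown leave open whether changing the group at this spot shifts the half-maximal cytotoxic concentration at all, and by how much.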